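Benzimidazole-free notes: thioether series, phenethyl to benzylsulfanyl swap

The source may hold more compounds than are shown below. What is called first, only, known or untested is meant among the compounds shown, and "the series" means these compounds.

Measured so far in an assay on isolated protein for inhibition of Indoleamine 2,3-dioxygenase 1 (Homo sapiens), with a stated time of 60 min, tested at 10 uM; a lower number here means less inhibition, a higher number more inhibition at the concentration tested (going by the name of the read-out):
- compound 1, `Clc1ccc2[nH]c(SCc3ccccc3CCc3ccccc3)nc2c1`, gives 47%
- compound 2, `Clc1ccc2sc(SCc3ccccc3CCc3ccccc3)nc2c1`, gives 9%
- compound 3, `c1ccc(CSc2nc3ccccc3[nH]2)cc1`, gives -42%

Compound 1 holds the highest of the three numbers. Compound 2 is nearest, a number lower by a gap beyond the scatter; compound 3 is furthest, lower by a gap well beyond the scatter. No pair of these compounds differs in a single place, so no step between measured compounds can be read off, and nothing here separates the contribution of the core from that of the side chain.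

The next compound, compound 4, `Clc1ccc2[nH]c(SCc3ccccc3SCc3ccccc3)nc2c1`, keeps the core of compound 1 and changes the side chain only: benzylsulfanyl in place of phenethyl on an aromatic carbon. The group that leaves and the group that enters are of the same size and carry the same kind of aromatic ring; the difference lies in one atom and one hydrogen-bond acceptor.

Going by the values given here, with no measured step of this kind to lean on, the expected step in this assay from compound 1 to compound 4 is small, in either direction or none beyond the scatter, estimated as a number 7 percentage points lower from compound 1 to compound 4 (within the scatter). Compound 4 is therefore expected to give about 40% in this assay, within a range of 10% to 65%.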

Compound 4, a percentage reported as inhibition, at one concentration (the size of the read-out at that concentration, not a potency): 19%
Compound 4: the middle estimate sits 21 percentage points above what was measured, and the stated range covers the measured number.
By their numbers in this assay, from the lowest: compound 3; then compounds 2 and 4 (each within the scatter of the next); then compound 1.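

In this assay, going by these compounds alone, benzylsulfanyl in place of phenethyl gives a number 28 percentage points lower from compound 1 to compound 4 (beyond the scatter) and is the first step that can be read with the core of compound 1 held fixed. This shows that the side chain at this position, on an aromatic carbon of a six-membered aromatic ring of carbon only and ortho to a large group, is not indifferent to the exchange, even though the leaving and entering groups have equal heavy-atom counts and the same kind of aromatic ring; what separates them on the count is a sulfur atom in place of a carbon and one hydrogen-bond acceptor. Nothing available explains why the number falls with this change.

This single step cannot separate the sulfur atom as such from its place in the chain, and a benzyloxy group, with an oxygen atom in the same place, would bear directly on that question. Within the data shown here, whether a longer chain such as phenylpropyl is accepted here also remains open, as does the contribution of the core, which no single-place step yet isolates.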